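Lengthening the amine chain of compound 2

The compounds below may be only part of what the source reports. "The series", "measured", "known", "first", "only" and "open" are said of these compounds alone.

- Compound 1 (`CCCCCOc1c(-c2cc(OC)c(OC)c(OC)c2)oc2ccccc2c1=O`): > 50000 nM (a limit)
- Compound 2 (`CCCCN(CCCC)CCCOc1c(-c2cc(OC)c(OC)c(OC)c2)oc2ccccc2c1=O`): 15700 nM

Within the data shown here, in a functional assay on DU-145 cells (Homo sapiens) for antiproliferative activity, read by WST assay, with a stated time of 3 days (on this read-out lower numbers stand for stronger inhibition and higher numbers for weaker inhibition), compound 2 gives 15700 nM, the only true number so far. Compound 1 gives > 50000 nM, which is a limit of the assay and not a number. Among the measured compounds shown here, the one measured step is an at least 3.1-fold lower number from compound 1 to compound 2 (0.50 log units; beyond the scatter), where dibutylamino replaces ethyl. Its size is only a bound because of the limit of > 50000 nM in this assay, at which 1 of the 2 values shown sits.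

Compound 3 (`CCCCN(CCCC)CCCCCOc1c(-c2cc(OC)c(OC)c(OC)c2)oc2ccccc2c1=O`) carries 2-(dibutylamino)ethyl in place of dibutylamino on a saturated chain carbon, three bonds along the chain from an oxygen on an aromatic ring. This keeps the dibutylamino end and changes only the chain that carries it. For the measured compounds named here, no measured step covers that change, so the step to compound 2 offers only indirect guidance: compound 3 retains the group that came with the lower number. A small move towards a lower number in this assay is expected, perhaps no larger than the scatter, and the expected step is a 1.4-fold lower number from compound 2 to compound 3 (0.15 log units; within the scatter). Compound 3 is estimated at 11000 nM, with an expected range of 4000 nM to 30000 nM.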

Compound 3, half-maximal inhibitory concentration: > 50000 nM
Compound 3: no number, only a limit; the forecaster's own chance of this, stated with the estimate: 10%; middle value at least 4.5-fold (0.65 log units) from the limit.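

In this assay compound 3 gives > 50000 nM, which is a limit of the assay and not a number. Lengthening the chain while keeping the dibutylamino end gives an at least 3.1-fold higher number from compound 2 to compound 3 (0.50 log units; beyond the scatter), so the amine end alone does not secure the lower number of compound 2, and the length of the chain that carries it matters too. This step is only a bound, and the step between compound 1 and compound 3 cannot be read, because these values rest on the same assay limit: the limit of > 50000 nM in this assay, at which 2 of the 3 values shown sit.

Among these compounds, how far compound 3 truly lies from compound 2 stays unknown, and with only one true number, the two compounds give no trend along the chain, only a sign that the longer chain of compound 3 does not keep the activity of compound 2. Also open, on these data alone, are whether a chain of a length between those of compound 2 and compound 3 would keep the lower number, and whether a smaller amine such as dimethylamino, or a ring amine such as piperidine, on the chain of compound 2 would lower it further.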